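Piperidin-4-yl to methyl on the pyrazole series

This account rests on a few compounds, and the source may have more. Where it says the series, first, only, none or still open, it means among the compounds named here.

Measured in a functional assay on SK-BR-3 cells (Homo sapiens) for antiproliferative activity, read by MTT assay, with a stated time of 72 h; on this read-out higher numbers stand for weaker inhibition and lower numbers for stronger inhibition:
- compound 1 `CC(Nc1ncnc2ccc(-c3cnn(C4CCNCC4)c3)cc12)c1c(Cl)ccc(F)c1Cl`: 4390 nM
- compound 2 `CC(Nc1nc(N)nc2ccc(-c3cnn(C4CCNCC4)c3)cc12)c1c(Cl)ccc(F)c1Cl`: 1580 nM
- compound 3 `CC(Oc1nc(N)nc2ccc(-c3cnn(C4CCNCC4)c3)cc12)c1c(Cl)ccc(F)c1Cl`: 7120 nM

Compound 2 stands lowest of the three numbers in this assay, with a clear gap to the other two. At 1580 nM, compound 2 lies under compound 1 at 4390 nM, and further under compound 3 at 7120 nM.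

The next compound is compound 4 `CC(Nc1nc(N)nc2ccc(-c3cnn(C)c3)cc12)c1c(Cl)ccc(F)c1Cl`, not yet measured. Its change from compound 2 is methyl in place of piperidin-4-yl on an aromatic nitrogen. Within the data shown here, all three measured compounds carry piperidin-4-yl, so no measured step touches this place. Among the measured compounds shown here, the only step available, a 2.8-fold lower number from compound 1 to compound 2 (0.44 log units; beyond the scatter), is a modest one, made elsewhere on the molecule as amino in place of hydrogen on an aromatic carbon. It offers a rough guide to size and none to direction.

A step of modest size is therefore expected, with a slight lean towards a higher number that the data cannot confirm. On these data alone, the expected change is a 1.6-fold higher number from compound 2 to compound 4 (0.20 log units; within the scatter), and the direction remains open. For compound 4 the estimated value is 2500 nM, with an expected range from 700 nM to 9000 nM.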

Compound 4, half-maximal inhibitory concentration: 7140 nM
Estimate against measurement, compound 4: 2.9-fold (0.46 log units) below; the measured number falls inside the stated range.
By their numbers in this assay, from the lowest: compound 2; then compounds 1, 3 and 4 (each within the scatter of the next).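

In this assay, substitution on an aromatic nitrogen of the five-membered aromatic ring proves to be a place that responds to change: a 4.5-fold higher number from compound 2 to compound 4 (0.66 log units; beyond the scatter), a shift towards weaker inhibition and beyond the scatter. Methyl in place of piperidin-4-yl therefore does not preserve the activity of compound 2, at least on this core, and the piperidin-4-yl form is the better of this single pair. The change removes the six-membered non-aromatic ring, its ring nitrogen and five of the carbons together, and no measurement available here gives a reason for the shift.

This pair cannot separate the part played by the ring carbons from that of the ring nitrogen, so groups such as cyclohexyl, tetrahydropyran-4-yl or a 2-aminoethyl chain would be needed to tell these apart. The step is also read only on the core of compound 2, which leaves open whether methyl in place of piperidin-4-yl has a similar size on the core of compound 1 or that of compound 3.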